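This account rests on a few compounds, and the source may have more. Where it says the series, first, only, none or still open, it means among the compounds named here.

Compound 1 `O=C(Nc1ccccc1)c1cccc(/C=C2\CC(=O)N(c3ccccc3)C2=O)c1`: > 100000 nM
Compound 2 `Cc1cccc(NC(=O)c2cccc(/C=C3\CC(=O)N(c4ccccc4)C3=O)c2)c1`: > 100000 nM

In an ADME assay on NCM460 cells (Homo sapiens) for cytotoxicity, read by MTT assay, with a stated time of 72 h (on this read-out higher numbers stand for weaker inhibition and lower numbers for stronger inhibition), compound 1 gives > 100000 nM, which is a limit of the assay rather than a number. Compound 2, in this assay, gives > 100000 nM, again a limit. Among the compounds with values here, the one step measured so far, a step that the two limits leave unreadable from compound 1 to compound 2, therefore cannot be sized. What the data do show is the limit of > 100000 nM in this assay, at which 2 of the 2 values shown sit, so neither measured compound reached a readable inhibition.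

Compound 3 `COc1ccc(NC(=O)c2cccc(/C=C3\CC(=O)N(c4ccccc4)C3=O)c2)c(C)c1` is unmeasured. It differs from compound 1 by 4-methoxy-2-methylphenyl in place of phenyl on an amide-type nitrogen. Within the data shown here, no measured step bears on this change directly, and the single known step is unreadable. Given that both measured compounds sit at the limit of > 100000 nM in this assay, at which 2 of the 2 values shown sit, the step from compound 1 to compound 3 is expected to be a step that the limit leaves unreadable from compound 1 to compound 3, that is, no change beyond the scatter. Compound 3 is thus expected to give about 150000 nM in this assay, within a range of 70000 nM to 400000 nM, most likely again reported only as a limit.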

Compound 3, half-maximal inhibitory concentration: > 100000 nM
Compound 3 gave a limit, no number (the forecaster's own chance of this, stated with the estimate: 80%); the middle value does not contradict the limit.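

In this assay compound 3 also gives a limit rather than a number, so neither step to it, from compound 1 or from compound 2, can be read: the limit of > 100000 nM in this assay, at which 3 of the 3 values shown sit.

The compounds shown leave open whether any group on the amide-type nitrogen could bring a readable inhibition in this assay.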